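The compounds below may be only part of what the source reports. "The series", "measured", "known", "first", "only" and "open" are said of these compounds alone.

Measured so far in a functional assay on KYSE-450 cells (Homo sapiens) for inhibition, read by MTT assay, with a stated time of 48 h; on this read-out higher numbers stand for weaker inhibition and lower numbers for stronger inhibition:
compound 1 `COc1ccc(CNc2cc(OC)c(OC)c(OC)c2)cc1Br`, 39800 nM
compound 2 `C/C=C/C(=O)N(Cc1ccc(OC)c(Br)c1)c1cc(OC)c(OC)c(OC)c1`, 10500 nM

Compound 1 gives the highest of the two numbers; its nearest neighbour is compound 2, reached by a 3.8-fold lower number from compound 1 to compound 2 (0.58 log units; beyond the scatter), a change of (prop-1-en-1-yl)carbonyl in place of hydrogen on a nitrogen on an aromatic ring. Compound 3 `COc1ccc(CNc2cc(OC)c(OC)c(OC)c2)cc1C` is not yet measured. It differs from compound 1 by methyl in place of bromo on an aromatic carbon. Going by the values given here, no measured step touches that position, so nothing bears directly on the change. The step of a 1.0-fold higher number from compound 1 to compound 3 (0.00 log units; within the scatter) is expected to stay within the scatter. Compound 3 is estimated at 40000 nM in this assay, with a range from 15000 nM to 100000 nM.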

Compound 3, half-maximal inhibitory concentration: 73800 nM
The estimate for compound 3 lay 1.8-fold (0.27 log units) below the measured number; low and high end bracket the measured number.
By their numbers in this assay, from the lowest: compound 2; then compounds 1 and 3 (each within the scatter of the next).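

In this assay, methyl in place of bromo on an aromatic carbon ortho to a methoxy group gives a 1.9-fold higher number from compound 1 to compound 3 (0.27 log units; within the scatter). Going by these compounds alone, this is the first reading at this position, and across this single swap, bromo and methyl cannot be told apart in this read-out. No supporting data bear on the outcome of this swap.

Open, on these data alone, is whether an amine, a carboxylic acid or a longer chain at this position would move the number beyond the scatter. Also open, as far as these compounds go, is whether methyl in place of bromo reads the same with (prop-1-en-1-yl)carbonyl on the nitrogen.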